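This account rests on a few compounds, and the source may have more. Where it says the series, first, only, none or still open, it means among the compounds named here.

Compound 3 `O=C1c2cc(COc3ccccc3)nn2CCN1c1ccncc1` gives 72% in a functional assay on HEK293 cells for positive allosteric modulation of metabotropic glutamate receptor 5 (Homo sapiens), read by calcium flux (a lower number here means a smaller maximal response, a higher number a larger maximal response), the lowest of the three measured numbers, with compound 1 `O=C1c2cc(COc3ccccc3)nn2CCN1c1cccc(F)c1` at 81% and compound 2 `O=C1c2cc(COc3ccccc3)nn2CCN1c1ccc(F)c(F)c1` at 81%, both of which lie within the scatter of compound 3. Compound 4 `COc1ccc(N2CCn3nc(COc4ccccc4)cc3C2=O)nc1` differs from compound 3 in one place: 5-methoxypyridin-2-yl in place of pyridin-4-yl on an amide-type nitrogen in a ring. The measured steps that bear on this change also exchanged the ring on the amide-type nitrogen in a ring: a number 9 percentage points lower from compound 1 to compound 3 (within the scatter) and a number 9 percentage points lower from compound 2 to compound 3 (within the scatter), and no change at the digits printed from compound 1 to compound 2 (within the scatter) was likewise within the scatter. Since every such exchange seen so far left the maximal response essentially where it was, no step beyond the scatter is expected for compound 4 in this assay, a number 3 percentage points higher from compound 3 to compound 4 (within the scatter). Compound 4 is therefore estimated at 75%, within a range from 60% to 90%.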

Compound 4, largest response reached (Emax), in percent of the reference or control that the assay uses: 74%
The estimate for compound 4 lay 1 percentage points above the measured number; low and high end bracket the measured number.
By their numbers in this assay, from the lowest: compounds 3, 4, 1 and 2 (each within the scatter of the next).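

In this assay, 5-methoxypyridin-2-yl in place of pyridin-4-yl on the amide-type nitrogen in a ring gives a number 2 percentage points higher from compound 3 to compound 4 (within the scatter), so this position also accepts a pyridine ring carrying a methoxy group. The same group set against the fluorinated phenyl rings gives a number 7 percentage points lower from compound 1 to compound 4 (within the scatter) and a number 7 percentage points lower from compound 2 to compound 4 (within the scatter), which leaves all four rings on this nitrogen within the scatter of one another. No measurement here accounts for this. Going by these compounds, what stays open is whether a carboxylic acid or an amine on this ring, or a saturated ring such as piperidine on this nitrogen, would hold the maximal response.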